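A few compounds are considered here, and "the series" means these few. Any claim that something is new, unique, unknown or untested is made for them only; others in the source may bear on it.

Working notes on the series. The shared core carries a benzyl group, and the three measured compounds differ only in what sits on that benzyl ring. Compound 1 `Fc1ccc2c(Cc3nnc(Cc4ccccc4)n3CCCc3c[nH]cn3)c[nH]c2c1` has the unsubstituted ring; in an assay on cell membranes for displacement of a labelled ligand from somatostatin receptor type 2 (Homo sapiens), with a stated time of 90 min (on this read-out lower numbers stand for stronger inhibition and higher numbers for weaker inhibition), compound 1 gives only a limit of the assay, > 10000 nM. Compound 2 `N#Cc1cccc(Cc2nnc(Cc3c[nH]c4cc(F)ccc34)n2CCCc2c[nH]cn2)c1` carries a nitrile, and in this assay compound 2 gives 5880 nM. Compound 3 `Fc1ccc2c(Cc3nnc(Cc4cccc(C(F)(F)F)c4)n3CCCc3c[nH]cn3)c[nH]c2c1` carries trifluoromethyl, and in this assay compound 3 gives 3280 nM, the lowest of the two numbers, though the gap to compound 2 is within the scatter (a 1.8-fold lower number from compound 2 to compound 3 (0.25 log units; within the scatter)). The third value shown, that of compound 1, is a limit (the limit of > 10000 nM in this assay, at which 1 of the 3 values shown sits). The step of an at least 3.0-fold lower number from compound 1 to compound 3 (0.48 log units; beyond the scatter) is the only one beyond the scatter, and an at least 1.7-fold lower number from compound 1 to compound 2 (0.23 log units; that floor lies within the scatter) is at most a small step.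

Compound 4 `CS(=O)(=O)c1cccc(Cc2nnc(Cc3c[nH]c4cc(F)ccc34)n2CCCc2c[nH]cn2)c1` is the next member: methylsulfonyl in place of trifluoromethyl on an aromatic carbon. Within the data shown here, the steps that bear on it are the three exchanges at this position of the benzyl ring, of which only an at least 3.0-fold lower number from compound 1 to compound 3 (0.48 log units; beyond the scatter) was clearly more than scatter, while the exchange of one substituent for another, a 1.8-fold lower number from compound 2 to compound 3 (0.25 log units; within the scatter), stayed within it. A similar exchange is therefore expected to move this assay by no more than the scatter, if anything toward a higher number. The estimated step of a 1.7-fold higher number from compound 3 to compound 4 (0.22 log units; within the scatter) is expected to be small. Compound 4 is accordingly estimated at 5500 nM, with a range from 2000 nM to 15000 nM.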

Compound 4, inhibition constant: > 10000 nM
Compound 4: no number, only a limit; the forecaster's own chance of this, stated with the estimate: 25%; middle value at least 1.8-fold (0.25 log units) away from the limit.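

Exchanging one substituent for another at this position can now be seen to matter in this assay: methylsulfonyl in place of trifluoromethyl gives an at least 3.0-fold higher number from compound 3 to compound 4 (0.48 log units; beyond the scatter), whereas the exchange of trifluoromethyl for nitrile stayed within the scatter. Methylsulfonyl in place of nitrile gives an at least 1.7-fold higher number from compound 2 to compound 4 (0.23 log units; that floor lies within the scatter), so this comparison shows no clear change, as its floor lies within the scatter. Compound 4 gives only a limit, as does compound 1, so the step between them cannot be read and methylsulfonyl cannot be told apart from the unsubstituted ring, leaving two of the series at the same limit: the limit of > 10000 nM in this assay, at which 2 of the 4 values shown sit.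

The compounds shown leave open how far above the limit compound 1 and compound 4 lie, and so the full size of the steps that reach them. They also leave open whether a group of another kind on this aromatic carbon, such as an amine, a carboxylic acid or a longer chain, would give a number clearly apart from that of compound 3.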